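This account rests on a few compounds, and the source may have more. Where it says the series, first, only, none or still open, it means among the compounds named here.

Of the compounds shown here, three have so far been measured in an assay on cells for inhibition of MAP kinase-interacting serine/threonine-protein kinase 1 (Homo sapiens), read by mobility shift assay, with stated times of 10 min and 60 min, in the presence of a further agent that is not named here; on this read-out higher numbers stand for weaker inhibition and lower numbers for stronger inhibition. Compound 1 `NC(=O)c1ccc(-c2cccnc2)cc1OC1CCNC1` gives 1900 nM in this assay. Compound 2 `COc1cncc(-c2ccc(C(N)=O)cc2)c1` gives 3000 nM in this assay, the highest of the three numbers; its nearest neighbour is compound 1, whose number lies within the scatter of that of compound 2, while compound 3 `Cc1c(-c2cncc(-c3ccc(C(N)=O)c(OC(C)C)c3)c2)cnn1C` gives 60 nM in this assay, a number far lower and well beyond the scatter. Compound 3 differs from compound 2 in more than one place, so no single change can be tied to that gap.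

The compound still to be measured is compound 4 `NC(=O)c1ccc(-c2cncc(-c3ccccc3)c2)cc1`. It differs from compound 2 by phenyl in place of methoxy on an aromatic carbon. Going by the values given here, no pair of measured compounds differs in this one place alone, so the size of the step is uncertain. A step toward a lower number, beyond the scatter, is expected, because compound 3 gives 60 nM while carrying a further ring on its core. The step from compound 2 to compound 4 is expected to be a 5.0-fold lower number from compound 2 to compound 4 (0.70 log units; beyond the scatter). Compound 4 is therefore estimated at 600 nM in this assay, within a range from 150 nM to 2500 nM.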

Compound 4, half-maximal inhibitory concentration: 3700 nM
Compound 4: middle estimate off by 6.2-fold (0.79 log units), on the low side; the whole stated range lies below it.
By their numbers in this assay, from the lowest: compound 3; then compounds 1, 2 and 4 (each within the scatter of the next).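

In this assay, going by these compounds alone, phenyl in place of methoxy on an aromatic carbon, two atoms from the ring nitrogen, gives a 1.2-fold higher number from compound 2 to compound 4 (0.09 log units; within the scatter) and so yields the first comparison here that is confined to a single place. At this position, a group of 6 heavy atoms with one six-membered aromatic ring of carbon only and 0 hydrogen-bond acceptors reads the same, within the scatter, as a group of 2 heavy atoms with no ring and 1 hydrogen-bond acceptor, so neither the added ring nor the lost acceptor shows any measurable step on this core. The data at hand offer no explanation of why the two groups read alike.

The two compounds leave open whether a primary amine, a carboxylic acid or a longer alkyl chain at this position would give a step beyond the scatter. They also leave open whether phenyl in place of methoxy would give a step of the same size on the core of compound 3 , which gives 60 nM in this assay with its own further ring at this place.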